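This account rests on a few compounds, and the source may have more. Where it says the series, first, only, none or still open, it means among the compounds named here.

Measured in a functional assay on HCT-116 cells (Homo sapiens) for antiproliferative activity, read by MTT assay; a higher number here means a weaker inhibitor, a lower number a stronger inhibitor:
- Compound 1 `Cc1cccc(/C=N/Nc2ncc3c(n2)n(C2CCCC2)c(=O)c(=O)n3C)c1`: > 100000 nM (a limit)
- Compound 2 `Cn1c(=O)c(=O)n(C2CCCC2)c2nc(N/N=C/c3ccc(C(F)(F)F)cc3)ncc21`: 29000 nM
- Compound 3 `Cn1c(=O)c(=O)n(C2CCCC2)c2nc(N/N=C/c3cccc(O)c3)ncc21`: 37200 nM

Compound 3 sits within the scatter of compound 2, with a 1.3-fold higher number from compound 2 to compound 3 (0.11 log units; within the scatter). Compound 4 `Cn1c(=O)c(=O)n(C2CCCC2)c2nc(N/N=C/c3ccccc3Cl)ncc21` has 2-chlorophenyl in place of 3-hydroxyphenyl on a carbon with a double bond to nitrogen. The closest measured exchange on this carbon is a 1.3-fold higher number from compound 2 to compound 3 (0.11 log units; within the scatter), which stays within the scatter. Two other exchanges, an at least 3.4-fold lower number from compound 1 to compound 2 (0.53 log units; beyond the scatter) and an at least 2.6-fold lower number from compound 1 to compound 3 (0.42 log units; beyond the scatter), lie beyond the scatter, so a weaker outcome remains possible. Going by these compounds, both of these steps start from a limit, so their true size is unknown. No step beyond the scatter is therefore expected, and the expected change is a 1.1-fold higher number from compound 3 to compound 4 (0.03 log units; within the scatter). Compound 4 is estimated at 40000 nM, with an expected range of 15000 nM to 100000 nM.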

Compound 4, half-maximal inhibitory concentration: 14000 nM
Compound 4: the middle estimate sits 2.9-fold (0.46 log units) above what was measured, and the stated range ends above it.
By their numbers in this assay, from the lowest: compound 4; then compounds 2 and 3 (each within the scatter of the next). At a limit, above all of these: compound 1.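

Here a 2.7-fold lower number from compound 3 to compound 4 (0.42 log units; beyond the scatter) and a 2.1-fold lower number from compound 2 to compound 4 (0.32 log units; beyond the scatter) show that, in this assay, 2-chlorophenyl on a carbon with a double bond to nitrogen separates beyond the scatter from 3-hydroxyphenyl and 4-(trifluoromethyl)phenyl. Among the compounds shown here, these are the first exchanges at this carbon beyond the scatter that do not start from a limit. By contrast, an at least 7.1-fold lower number from compound 1 to compound 4 (0.85 log units; beyond the scatter) gives only a bound, as compound 1 stands at a limit: the limit of > 100000 nM in this assay, at which 1 of the 4 values shown sits.

Going by these compounds, whether the result depends on where the chlorine sits on the phenyl ring remains open. So does the outcome with an amine or a carboxylic acid on that ring.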